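The compounds below may be only part of what the source reports. "The series", "measured", "known", "first", "only" and "open" are said of these compounds alone.

Notes on the series. Compound 1 `Cc1ccc(S(=O)(=O)NCc2ccc(CNC(=O)c3ccc(F)cc3)cc2)cc1` gives 1 nM in an assay on MDA-MB-231 cells for binding affinity to C-X-C chemokine receptor type 4 (Homo sapiens), read by immunofluorescence and microscopy, with stated times of 10 min and 30 min (on this read-out higher numbers stand for an effect only at larger amounts of compound and lower numbers for an effect already at smaller amounts), level with compound 3 `COc1ccccc1C(=O)NCc1ccc(CNS(=O)(=O)c2ccccc2)cc1`, which gives 1 nM; the two stand together at the lowest of the three numbers, while compound 2 `O=C(NCc1ccc(CNS(=O)(=O)c2ccccc2)cc1)c1ccc(F)cc1` gives 100 nM, the highest of them. The step of a 100-fold higher number from compound 1 to compound 2 (2.00 log units; beyond the scatter) arises from hydrogen in place of methyl on an aromatic carbon. The step of a 100-fold lower number from compound 2 to compound 3 (2.00 log units; beyond the scatter) arises from 2-methoxyphenyl in place of 4-fluorophenyl on a carbonyl carbon.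

Compound 4 `Cc1ccc(S(=O)(=O)NCc2ccc(CNC(=O)c3cccc(Cl)c3)cc2)cc1` is not yet measured. It differs from compound 1 by 3-chlorophenyl in place of 4-fluorophenyl on a carbonyl carbon. Among the compounds with values here, of the measured steps only a 100-fold lower number from compound 2 to compound 3 (2.00 log units; beyond the scatter) concerns the same place, and it shows that the aryl on the carbonyl carbon can move the number greatly; no measured compound carries 3-chlorophenyl there, so the direction is not fixed by the data. Compound 1 already sits with the lowest numbers, which leaves more room upward than downward. For compound 4 the expected step is a 3.0-fold higher number from compound 1 to compound 4 (0.48 log units; beyond the scatter), a modest rise in the number. Compound 4 is therefore estimated at 3 nM, with a range from 0.5 nM to 30 nM.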

Compound 4, effective concentration (reported as EC, without a stated level of effect): 100 nM
Estimate against measurement, compound 4: 33-fold (1.52 log units) below; measured number above the stated range.
By their numbers in this assay, from the lowest: compounds 1 and 3 (each within the scatter of the next); then compounds 2 and 4 (each within the scatter of the next).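

The aryl on the carbonyl carbon now gives a large step with the methyl kept in place: a 100-fold higher number from compound 1 to compound 4 (2.00 log units; beyond the scatter) in this assay, where the earlier step at this position came only from compounds without that methyl. The methyl shared by compound 1 and compound 4 therefore does not by itself keep the number low, and 3-chlorophenyl and 4-fluorophenyl are far apart here even though they match in heavy-atom count, ring type, hydrogen-bond donors and acceptors, and net charge. No measurement at hand explains this difference between the two groups.

Going by these compounds, it remains open whether 2-methoxyphenyl would also give a low number on the methyl-bearing core of compound 1. On these data alone, the effect of an unsubstituted phenyl, or of an aryl carrying an amine or a carboxylic acid, at this carbonyl carbon also remains open.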